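The source may hold more compounds than are shown below. What is called first, only, known or untested is meant among the compounds shown, and "the series" means these compounds.

In a functional assay on the whole organism for inhibition, with Scenedesmus acutus as the target (a higher number here means a weaker inhibitor, a lower number a stronger inhibitor), compound 1 `O=C1C2=C(CCCC2)C(=O)N1c1ccc(Cl)cc1F` gives 37.2 nM, compound 2 `O=C(O)c1cc(N2C(=O)C3=C(CCCC3)C2=O)c(F)cc1Cl` gives 1000 nM and compound 3 `COC(=O)c1cc(N2C(=O)C3=C(CCCC3)C2=O)c(F)cc1Cl` gives 67.6 nM. Compound 3 thus stands within the scatter of compound 1 and well under compound 2. Compound 4 `CCOC(=O)c1cc(N2C(=O)C3=C(CCCC3)C2=O)c(F)cc1Cl` replaces its methoxycarbonyl with ethoxycarbonyl: methyl in place of hydrogen on a saturated chain carbon bound to an oxygen next to a carbonyl group. The closest evidence is the small step of a 1.8-fold higher number from compound 1 to compound 3 (0.26 log units; within the scatter), which introduces the ester. The large steps of a 27-fold higher number from compound 1 to compound 2 (1.43 log units; beyond the scatter) and a 15-fold lower number from compound 2 to compound 3 (1.17 log units; beyond the scatter) instead separate the free carboxy compound from the others. For the measured compounds named here, no measured step lengthens the ester chain, so the evidence is indirect. The expected change, a 1.1-fold lower number from compound 3 to compound 4 (0.05 log units; within the scatter), is none beyond the scatter, with no favoured direction. Compound 4 is estimated at 60 nM, with an expected range of 25 nM to 140 nM.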

Compound 4, half-maximal inhibitory concentration: 57.5 nM
For compound 4 the middle estimate is 1.0-fold (0.02 log units) above the measured one; measured number inside the range.
By their numbers in this assay, from the lowest: compounds 1, 4 and 3 (each within the scatter of the next); then compound 2.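

Ethoxycarbonyl in place of methoxycarbonyl extends the ester chain, a change no earlier pair covered, and in this assay the added methyl gives a 1.2-fold lower number from compound 3 to compound 4 (0.07 log units; within the scatter). The ethyl ester also stays close to the compound without an ester, with a 1.5-fold higher number from compound 1 to compound 4 (0.19 log units; within the scatter), while the step from the free acid, a 17-fold lower number from compound 2 to compound 4 (1.24 log units; beyond the scatter), shows that the large gap seen with the methyl ester holds for the ethyl ester too. No evidence here explains these results. On these data alone, whether a propyl or butyl chain, or an amide in place of the ester, would keep this level remains open.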